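A few compounds are considered here, and "the series" means these few. Any claim that something is new, unique, unknown or untested is made for them only; others in the source may bear on it.

Measured so far:
Compound 1 `O=C(C[C@H](NS(=O)(=O)c1ccc2ccccc2c1)c1ccccc1)NCc1ccc(CN2CCCCC2)cc1` in a functional assay on CHO cells for antagonist activity at B1 bradykinin receptor (Homo sapiens), read by calcium flux (a higher number here means a weaker inhibitor, a lower number a stronger inhibitor), gives <= 4000 nM, which is a limit of the assay rather than a number.
Compound 2 `O=C(C[C@@H](NS(=O)(=O)c1ccc2ccccc2c1)c1ccccc1)NCc1ccc(CN2CCCCC2)cc1` in this assay gives 447 nM.

Compound 2 thus holds the only number shown; the other value is a limit. The step that the limit leaves unreadable from compound 1 to compound 2 concerns configuration alone and its size cannot be read because of the limit of <= 4000 nM in this assay, at which 1 of the 2 values shown sits. Compound 3 `C[C@@H](NC(=O)C[C@@H](NS(=O)(=O)c1ccc2ccccc2c1)c1ccccc1)c1ccc(CN2CCCCC2)cc1` differs from compound 2 by methyl in place of hydrogen on a saturated chain carbon bound to an amide-type nitrogen and an aromatic carbon. Going by the values given here, no measured step touches such a methyl addition, so nothing measured bears on it, and a change within the scatter is expected, a 1.0-fold higher number from compound 2 to compound 3 (0.00 log units; within the scatter). Compound 3 is therefore estimated at 450 nM, between 150 nM and 1500 nM.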

Compound 3, half-maximal inhibitory concentration: 302 nM
For compound 3 the middle estimate is 1.5-fold (0.17 log units) above the measured one; low and high end bracket the measured number.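

In this assay the step is a 1.5-fold lower number from compound 2 to compound 3 (0.17 log units; within the scatter) when methyl replaces hydrogen on a saturated chain carbon bound to an amide-type nitrogen and an aromatic carbon. Going by these compounds alone, this is the first measured change at this place, and it shows that one added carbon there is tolerated, with no difference beyond the scatter. Nothing shown gives a reason for this result. Still open, from the compounds shown here alone, is whether a larger group on the same carbon, such as ethyl or hydroxymethyl, would read the same, and whether the opposite configuration at this carbon would.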